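Ethyl for Methyl on the Ring Nitrogen of the Shared Core

This account rests on a few compounds, and the source may have more. Where it says the series, first, only, none or still open, it means among the compounds named here.

Of the compounds shown here, three built on one shared core have so far been tested in a functional assay on HepG2 cells (Homo sapiens) for antiproliferative activity, read by MTT assay, with a stated time of 48 h; a lower number here means a stronger inhibitor, a higher number a weaker inhibitor. Compound 1 `N#CC1=C(N)Oc2c(c3nc4ccccc4nc3c3ccccc23)C12C(=O)N(Cc1cnnn1-c1cccc(Br)c1)c1ccccc12` gives only a limit there, > 50000 nM. Compound 2 `Cc1ccccc1-n1nncc1CN1C(=O)C2(C(C#N)=C(N)Oc3c(N)cc4nc5ccccc5nc4c32)c2ccccc21` likewise gives only a limit, > 50000 nM. Compound 3 `Cc1cccc(-n2nncc2CN2C(=O)C3(C(C#N)=C(N)Oc4c(N)cc5nc6ccccc6nc5c43)c3ccccc32)c1` also stops at a limit, > 50000 nM, so its standing can be stated only as that limit. All three values sit at the same place, (the limit of > 50000 nM in this assay, at which 3 of the 3 values shown sit). For the measured compounds named here, the single step between measured neighbours, a step that the two limits leave unreadable from compound 2 to compound 3, therefore cannot be read. Compound 4 `CCc1ccccc1-n1nncc1CN1C(=O)C2(C(C#N)=C(N)Oc3c(N)cc4nc5ccccc5nc4c32)c2ccccc21` differs from compound 3 by 2-ethylphenyl in place of 3-methylphenyl on an aromatic nitrogen. Going by the values given here, no measured step bears on this change, and every value so far is a limit, so the step that the limit leaves unreadable from compound 3 to compound 4 is expected to remain unreadable. For compound 4 the estimate is 70000 nM, with a range from 20000 nM to 250000 nM.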

Compound 4, half-maximal inhibitory concentration: 17900 nM
For compound 4 the middle estimate is 3.9-fold (0.59 log units) above the measured one; measured number outside the range, below it.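

Placing 2-ethylphenyl on the aromatic nitrogen gives the first readable change at this position in this assay: 2-ethylphenyl in place of 3-methylphenyl gives an at least 2.7-fold lower number from compound 3 to compound 4 (0.44 log units; beyond the scatter). Extending the methyl of 2-methylphenyl to ethyl gives an at least 2.7-fold lower number from compound 2 to compound 4 (0.44 log units; beyond the scatter). This position can therefore bring a compound off the limit, which the earlier compounds did not show: the limit of > 50000 nM in this assay, at which 3 of the 4 values shown sit.

As far as these compounds go, whether a propyl chain or an amine in place of the ethyl would lower the number further stays open. From the compounds shown here alone, the full size of both steps also stays open, since each starts from a limit.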